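The source may hold more compounds than are shown below. What is called first, only, known or untested is meant among the compounds shown, and "the series" means these compounds.

Measured in a functional assay on KB cells (Homo sapiens) for antiproliferative activity, read by sulforhodamine B assay, with a stated time of 3 days; on this read-out lower numbers stand for an effect already at smaller amounts and higher numbers for an effect only at larger amounts of compound:
- Compound 1 `CCC1=C(O)c2c(oc(-c3ccc(CBr)cc3)cc2=O)C(CC)(CC)C1=O`: > 46.5 uM, a limit of the assay
- Compound 2 `CCC1=C(O)c2c(oc(-c3cc(C)c(C)cc3C)cc2=O)C(CC)(CC)C1=O`: 8.2 uM
- Compound 3 `CCC1=C(O)c2c(oc(-c3ccc(OC)cc3C)cc2=O)C(CC)(CC)C1=O`: 20.9 uM

Of the two actual numbers, compound 3 holds the higher, at 20.9 uM, with a 2.5-fold higher number from compound 2 to compound 3 (0.41 log units; beyond the scatter). Compound 4 `CCC1=C(O)c2c(oc(-c3ccc(OC)c(Cl)c3)cc2=O)C(CC)(CC)C1=O` carries 3-chloro-4-methoxyphenyl in place of 4-methoxy-2-methylphenyl on an aromatic carbon, next to the ring oxygen (3-chloro-4-methoxyphenyl in place of 4-methoxy-2-methylphenyl on an aromatic carbon). Within the data shown here, no measured compound carries this group, so the only guides are the exchanges at the same place: a 2.5-fold higher number from compound 2 to compound 3 (0.41 log units; beyond the scatter) and an at least 2.2-fold lower number from compound 1 to compound 3 (0.34 log units; beyond the scatter), the second resting on a limit. A modest step or none beyond the scatter is therefore expected, and these data set no firm direction. The estimated change is a 1.4-fold lower number from compound 3 to compound 4 (0.14 log units; within the scatter). For compound 4 the expected value is 15 uM, within an estimated range of 5 uM to 45 uM.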

Compound 4, concentration for half-maximal effect: 24.9 uM
Compound 4: middle estimate off by 1.7-fold (0.22 log units), on the low side; the measured number falls inside the stated range.
By their numbers in this assay, from the lowest: compound 2; then compounds 3 and 4 (each within the scatter of the next). At a limit, above all of these: compound 1.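

Exchanging 4-methoxy-2-methylphenyl for 3-chloro-4-methoxyphenyl at this position leaves the result within the scatter, with a 1.2-fold higher number from compound 3 to compound 4 (0.08 log units; within the scatter). Among these compounds, the 2,4,5-trimethylphenyl group stays apart from the new group, with a 3.0-fold higher number from compound 2 to compound 4 (0.48 log units; beyond the scatter), so it remains the only group here with a number beyond the scatter of the others. Against 4-(bromomethyl)phenyl the step is an at least 1.8-fold lower number from compound 1 to compound 4 (0.27 log units; that floor lies within the scatter), and it rests on a limit: the limit of > 46.5 uM in this assay, at which 1 of the 4 values shown sits.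

The compounds shown leave open whether a phenyl ring carrying an amine or a carboxylic acid at this position would give a number apart from these.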